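A Second Methyl Replaces the Hydroxyl on the Pendant Ring

The compounds below may be only part of what the source reports. "The series", "measured", "known", "first", "only" and "open" are said of these compounds alone.

Of the compounds shown here, three sharing one core have been tested in a functional assay on Jurkat cells (Homo sapiens) for antiproliferative activity, read by MTT assay; a higher number here means a weaker inhibitor, a lower number a stronger inhibitor. Compound 1 `COc1cc2c(cc1OC)C(=O)/C(=C/c1cccc(Cl)c1)CC2` gives 9000 nM, compound 2 `COc1cc2c(cc1OC)C(=O)/C(=C/c1cccc(C)c1)CC2` gives 17000 nM, and compound 3 `COc1cc2c(cc1OC)C(=O)/C(=C/c1ccc(O)cc1)CC2` gives 19000 nM, the highest number of the three. The change to compound 4 `COc1cc2c(cc1OC)C(=O)/C(=C/c1cc(C)cc(C)c1)CC2` is 3,5-dimethylphenyl in place of 4-hydroxyphenyl on a double-bonded chain carbon bound to a double-bonded ring carbon. The closest measured steps are a 1.1-fold higher number from compound 2 to compound 3 (0.05 log units; within the scatter) and a 2.1-fold higher number from compound 1 to compound 3 (0.32 log units; beyond the scatter), so swapping this pendant ring has so far moved the numbers only slightly. Compound 4 is therefore expected to show a small step downward, a 1.4-fold lower number from compound 3 to compound 4 (0.13 log units; within the scatter), in line with compound 2 and its value 17000 nM. The estimate for compound 4 is 14000 nM, with a range from 6000 nM to 35000 nM.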

Compound 4, half-maximal inhibitory concentration: 4000 nM
The estimate for compound 4 lay 3.5-fold (0.54 log units) above the measured number; the whole stated range lies above it.
By their numbers in this assay, from the lowest: compound 4; then compounds 1, 2 and 3 (each within the scatter of the next, the first and the last beyond it).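

Among the first three compounds, changing the pendant ring moved the numbers only slightly, but in this assay adding a methyl on an aromatic carbon gives a larger step (a 4.3-fold lower number from compound 2 to compound 4 (0.63 log units; beyond the scatter)). The 3,5-dimethylphenyl ring also gives lower numbers than the 4-hydroxyphenyl ring (a 4.8-fold lower number from compound 3 to compound 4 (0.68 log units; beyond the scatter)) and the 3-chlorophenyl ring (a 2.3-fold lower number from compound 1 to compound 4 (0.35 log units; beyond the scatter)), so this position is more sensitive than it first appeared. Nothing available explains this gain. Still open, going by these compounds, is whether it is specific to methyl, or whether two ethyl groups or two chloro groups would match it. On these data alone, an amine or a carboxylic acid on the ring also remains untested here.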